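Acid half-life notes: from compound 1 to compound 4

The source may hold more compounds than are shown below. What is called first, only, known or untested is meant among the compounds shown, and "the series" means these compounds.

Compound 1 `N[C@@H](CSNC(=O)[C@@H](CCC(F)(F)F)N(Cc1ccc(-c2ncon2)cc1F)S(=O)(=O)c1ccc(Cl)cc1)C(=O)O` gives > 500 h
Compound 2 `COC(=O)[C@@H](N)CSNC(=O)[C@@H](CCC(F)(F)F)N(Cc1ccc(-c2ncon2)cc1F)S(=O)(=O)c1ccc(Cl)cc1` gives > 500 h
Compound 3 `N#CCCSNC(=O)[C@@H](CCC(F)(F)F)N(Cc1ccc(-c2ncon2)cc1F)S(=O)(=O)c1ccc(Cl)cc1` gives > 500 h

All three values in a physicochemical assay for pharmacokinetics, at pH 1, tested at 100 ug/mL (a higher number here means that the compound lasts longer, a lower number that the compound disappears faster), are limits of the assay, not numbers. Compound 1 stands at that limit, and so do the other two (the limit of > 500 h in this assay, at which 3 of the 3 values shown sit). Compound 4 `NCCSNC(=O)[C@@H](CCC(F)(F)F)N(Cc1ccc(-c2ncon2)cc1F)S(=O)(=O)c1ccc(Cl)cc1` differs from compound 1 by hydrogen in place of carboxy on a saturated chain carbon bound to an amine nitrogen and a saturated chain carbon. The measured steps that bear on it are a step that the two limits leave unreadable from compound 1 to compound 2 and a step that the two limits leave unreadable from compound 1 to compound 3; both alter the same part of the shared core as the present change, yet neither is readable in size. No step beyond the scatter can be expected in this assay, and the likely outcome for compound 4 is again a limit. Compound 4 is estimated at 600 h (range 150 h to 2000 h), an expected step that the limit leaves unreadable from compound 1 to compound 4.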

Compound 4, half-life: > 500 h
Compound 4 was reported as a limit; the forecaster's own chance of this, stated with the estimate: 85%; the middle value is on the limit's open side.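

No step can be read among compound 1, compound 2, compound 3 and compound 4 in this assay, as all four values are limits of the assay: the limit of > 500 h in this assay, at which 4 of the 4 values shown sit.

The compounds shown leave open whether any change at this place alters the half-life at all.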